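Methyl Added to a Weak Disulfide-Isomerase Binder

This account rests on a few compounds, and the source may have more. Where it says the series, first, only, none or still open, it means among the compounds named here.

Compound 1 `Oc1ccc2[nH]ncc2c1C(c1ccc(-c2cncnc2)cc1)N1CCCCC1`: 830 nM
Compound 2 `CN(C)c1cccc(C(c2ccc(F)cc2)N2CCCCC2)c1O`: > 30000 nM
Compound 3 `Cc1ccnc(NC(c2ccccc2C)c2ccc3cccnc3c2O)c1`: > 40000 nM

In an assay for inhibition of protein disulfide-isomerase (Homo sapiens), with a stated time of 1 h (on this read-out lower numbers stand for stronger inhibition and higher numbers for weaker inhibition), compound 1 gives 830 nM. For compound 2 the assay reports only a limit, > 30000 nM. Compound 3 also yields only a limit, > 40000 nM, and so it sits at the limit of > 40000 nM in this assay, at which 1 of the 3 values shown sits; it is one of two compounds here with a limit rather than a number.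

Compound 4 `Cc1ccnc(NC(c2cc(C)ccc2C)c2ccc3cccnc3c2O)c1` differs from compound 3 by methyl in place of hydrogen on an aromatic carbon. Going by the values given here, no measured step of this kind is available, so no size beyond the scatter is expected in either direction. Because compound 3 already sits at the limit of > 40000 nM in this assay, at which 1 of the 3 values shown sits, compound 4 is expected to remain a limit as well, estimated at 60000 nM (between 20000 nM and 200000 nM). That estimate means an expected step that the limit leaves unreadable from compound 3 to compound 4.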

Compound 4, half-maximal inhibitory concentration: > 40000 nM
Compound 4 ended at the assay's limit; the forecaster's own chance of this, stated with the estimate: 85%; the middle value lies beyond the limit too.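

Compound 3 and compound 4 both end at a limit rather than a number, and the step between them cannot be read. On these data alone, whether this added methyl changes inhibition at all remains open.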